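Trifluoromethyl for Fluoro: From Compound 3 to Compound 4

The compounds below may be only part of what the source reports. "The series", "measured", "known", "first", "only" and "open" are said of these compounds alone.

compound 1 `COc1ccc(-n2ccc(=O)c(C(=O)Nc3ccc(Oc4ccnc5[nH]ccc45)c(F)c3)n2)cc1` — 46400 nM
compound 2 `Cn1ccc2c(Oc3ccc(NC(=O)c4nn(-c5ccc(Br)cc5)ccc4=O)cc3F)ccnc21` — > 60000 nM
compound 3 `Cc1cc(=O)n(-c2cccc(F)c2)nc1C(=O)Nc1ccc(Oc2ncnc3[nH]ccc23)cc1` — 14600 nM

In a functional assay on PC-3 cells (Homo sapiens) for cytotoxicity, read by MTT assay, with a stated time of 72 h (a lower number here means a stronger inhibitor, a higher number a weaker inhibitor), compound 1 gives 46400 nM. Compound 2 reports only a limit of the assay, > 60000 nM. Compound 3 gives 14600 nM, the lowest of the two numbers; compound 1 stands a step above it that lies beyond the scatter. The value of compound 2 is a limit, as noted in the limit of > 60000 nM in this assay, at which 1 of the 3 values shown sits.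

Compound 4 `Cc1cc(=O)n(-c2cccc(C(F)(F)F)c2)nc1C(=O)Nc1ccc(Oc2ncnc3[nH]ccc23)cc1` differs from compound 3 by trifluoromethyl in place of fluoro on an aromatic carbon. For the measured compounds named here, no pair of measured compounds shows such a change, so nothing measured sets the size of the step. The expectation is that compound 4 lands near compound 3, with a step of a 1.5-fold lower number from compound 3 to compound 4 (0.16 log units; within the scatter) that is expected to stay within the scatter. Compound 4 is estimated at 10000 nM, within 3000 nM to 40000 nM.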

Compound 4, half-maximal inhibitory concentration: 3460 nM
Estimate against measurement, compound 4: 2.9-fold (0.46 log units) above, within the range that was stated.
By their numbers in this assay, from the lowest: compound 4; then compound 3; then compound 1. At a limit, above all of these: compound 2.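

In this assay, for the compounds shown here, the change from 3-fluorophenyl to 3-(trifluoromethyl)phenyl gives a 4.2-fold lower number from compound 3 to compound 4 (0.63 log units; beyond the scatter) and so shows that this position on the aromatic ring responds to its substituent, which no earlier pair could show. The larger trifluoromethyl group is accepted here, with the number falling rather than rising. Nothing measured here accounts for the step. Open, as far as these compounds go, is how an amine or a methoxy group would fare at this position. Also open, from the compounds shown here alone, is whether trifluoromethyl brings a similar step on the core of compound 1.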